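A few compounds are considered here, and "the series" means these few. Any claim that something is new, unique, unknown or untested is made for them only; others in the source may bear on it.

Compound 2 `CC(C)(C)OC(=O)NCC1(O)CCN(CCCc2c[nH]c3ccc(-n4cnnc4)cc23)CC1` gives 21 nM in an assay on CHO cells with 5-hydroxytryptamine receptor 1D (Homo sapiens) as the target (a higher number here means a weaker inhibitor, a lower number a stronger inhibitor), the highest of the two numbers in hand; compound 1 `Cc1ccccc1CNCC1(O)CCN(CCCc2c[nH]c3ccc(-n4cnnc4)cc23)CC1` gives 4 nM. Within the data shown here, the one measured step that bears on the series is a 5.3-fold higher number from compound 1 to compound 2 (0.72 log units; beyond the scatter). Compound 3 `Cc1ccccc1CN(C)CC1(O)CCN(CCCc2c[nH]c3ccc(-n4cnnc4)cc23)CC1` differs from compound 2 by methyl(2-methylbenzyl)amino in place of (tert-butoxycarbonyl)amino on a saturated chain carbon bound to a saturated ring carbon. This largely reverses the measured step, with an added methyl within the amino group for which no comparison exists. In this assay the expected step is therefore a 4.2-fold lower number from compound 2 to compound 3 (0.62 log units; beyond the scatter), toward the number seen for compound 1. Compound 3 is estimated at 5 nM, with a range of 1.5 nM to 16 nM.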

Compound 3, half-maximal inhibitory concentration: 1.3 nM
Compound 3: middle estimate off by 3.8-fold (0.59 log units), on the high side; measured number outside the range, below it.
By their numbers in this assay, from the lowest: compound 3; then compound 1; then compound 2.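

Exchanging (tert-butoxycarbonyl)amino for methyl(2-methylbenzyl)amino gives a 16-fold lower number from compound 2 to compound 3 (1.21 log units; beyond the scatter) in this assay, so this position tolerates a tertiary amine carrying the 2-methylbenzyl group. Methyl in place of hydrogen on the amine nitrogen, a change the earlier compounds did not test, gives a 3.1-fold lower number from compound 1 to compound 3 (0.49 log units; beyond the scatter), so the amine hydrogen is not required for the low numbers in this pair. Nothing measured here explains either step.

As far as these compounds go, whether the methyl effect extends to larger nitrogen substituents remains open, as an ethyl group would show. Also open, from the compounds shown here alone, is whether it persists with an unsubstituted benzyl group on that nitrogen.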